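The compounds below may be only part of what the source reports. "The series", "measured", "known", "first", "only" and "open" are said of these compounds alone.

Measured in a physicochemical assay for solubility, read by HPLC, with a stated time of 4 h, at pH 2, tested at 10 mg/mL; a lower number here means a less soluble compound, a higher number a more soluble compound:
compound 1 `CCNC(=O)c1cc(N)c(Nc2ccc(C#N)cc2)cc1Oc1c(C)cc(CCC#N)cc1C` gives 69.4 ug/mL
compound 2 `Cc1cc(CCC#N)cc(C)c1Oc1cc(Nc2ccc(C#N)cc2)c(N)cc1CNC1CC1` gives 276 ug/mL
compound 3 `CC(=O)OCc1cc(N)c(Nc2ccc(C#N)cc2)cc1Oc1c(C)cc(CCC#N)cc1C` gives 2.63 ug/mL

Compound 3 stands lowest of the three in this assay: a 26-fold lower number from compound 1 to compound 3 (1.42 log units; beyond the scatter) and a 100-fold lower number from compound 2 to compound 3 (2.02 log units; beyond the scatter). Between the two higher compounds, a 4.0-fold higher number from compound 1 to compound 2 (0.60 log units; beyond the scatter).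

Compound 4 `Cc1cc(CCC#N)cc(C)c1Oc1cc(Nc2ccc(C#N)cc2)c(N)cc1COC(=O)C1CC1` differs from compound 3 by cyclopropyl in place of methyl on a carbonyl carbon. Among the measured compounds shown here, none of the measured steps touches the group on the carbonyl carbon; the two steps that reach compound 3, a 26-fold lower number from compound 1 to compound 3 (1.42 log units; beyond the scatter) and a 100-fold lower number from compound 2 to compound 3 (2.02 log units; beyond the scatter), exchange the acetoxymethyl group as a whole rather than the methyl on its carbonyl carbon. They put the ester compound far under the carbamoyl and amine compounds, and give no measure of what a larger group on the carbonyl carbon does. With the ester kept, no step beyond the scatter is expected in this assay, with a lean toward a somewhat lower number: a 1.8-fold lower number from compound 3 to compound 4 (0.24 log units; within the scatter). For compound 4 the estimate is 1.5 ug/mL, with a range from 0.4 ug/mL to 5 ug/mL.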

Compound 4, solubility: 1.24 ug/mL
Compound 4: the middle estimate sits 1.2-fold (0.08 log units) above what was measured, within the range that was stated.
By their numbers in this assay, from the lowest: compound 4; then compound 3; then compound 1; then compound 2.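

In this assay, among the compounds shown here, the group on the carbonyl carbon of the ester proves to be a place that can move the read-out on its own: cyclopropyl in place of methyl gives a 2.1-fold lower number from compound 3 to compound 4 (0.33 log units; beyond the scatter), a modest step, whereas the earlier steps only exchanged the acetoxymethyl group as a whole. The order of the series holds, with the new ester also far under the carbamoyl and amine compounds, at a 56-fold lower number from compound 1 to compound 4 (1.75 log units; beyond the scatter) and a 220-fold lower number from compound 2 to compound 4 (2.35 log units; beyond the scatter). Nothing available here bears on why this change lowers the number.

Methyl and cyclopropyl are the only groups shown on this carbonyl carbon, and a single step between them makes no trend. Open, on these data alone, is where a longer chain or a dimethylamino group on that carbon would fall relative to compound 3 and compound 4.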